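The compounds below may be only part of what the source reports. "The series", "measured", "known", "first", "only" and "open" are said of these compounds alone.

- Compound 1 `Cc1n[nH]c2c1C(c1ccc(N(C)C)cc1)C(C(=O)NNC(N)=S)=C(N)N2`: 6320 nM
- Compound 2 `Cc1n[nH]c2c1C(c1ccc(N(C)C)cc1)C(C(=O)NNc1cc([N+](=O)[O-])ccc1[N+](=O)[O-])=C(N)N2`: 8680 nM

Both compounds were tested in a functional assay on HepG2 cells (Homo sapiens) for cytotoxicity, read by MTT assay, with a stated time of 48 h; on this read-out higher numbers stand for weaker inhibition and lower numbers for stronger inhibition. Going by the values given here, compound 1 stands within the scatter of compound 2, its only measured neighbour, so the two cannot be ranked. Compound 3 `Cc1n[nH]c2c1C(c1ccc(N(C)C)cc1)C(C(=O)N/N=C/c1ccc(Cl)cc1)=C(N)N2` has not yet been measured. Its difference from compound 1 is a group of 9 heavy atoms (7 carbon, 1 nitrogen, 1 chlorine; one six-membered aromatic ring of carbon only) in place of a group of 4 heavy atoms (1 carbon, 2 nitrogen, 1 sulfur; no ring), on an amide-type nitrogen, on an amide-type nitrogen whose other neighbour is the carbonyl carbon. Among the compounds with values here, the one measured step that bears on this is a 1.4-fold higher number from compound 1 to compound 2 (0.14 log units; within the scatter). That step also brings in a larger group with a six-membered aromatic ring of carbon only, though on an amine nitrogen, and it stayed within the scatter. Two compounds are thin evidence, and neither carries the entering group. No change beyond the scatter is therefore expected in this assay. The expected step is a 1.0-fold higher number from compound 1 to compound 3 (0.01 log units; within the scatter). For compound 3 the estimated value is 6500 nM, with an expected range from 2500 nM to 17000 nM.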

Compound 3, half-maximal inhibitory concentration: 39500 nM
For compound 3 the middle estimate is 6.1-fold (0.78 log units) below the measured one, outside the stated range (above it).
By their numbers in this assay, from the lowest: compounds 1 and 2 (each within the scatter of the next); then compound 3.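

In this assay, the amide-type nitrogen whose other neighbour is the carbonyl carbon did not tolerate every group equally: the group of 9 heavy atoms, with its six-membered aromatic ring of carbon only and its chlorine, in place of the group of 4 heavy atoms gave a 6.3-fold higher number from compound 1 to compound 3 (0.80 log units; beyond the scatter). The earlier step, a 1.4-fold higher number from compound 1 to compound 2 (0.14 log units; within the scatter), had also brought in a larger group with such a ring and stayed within the scatter, so compound 2 goes against any rule that a larger aromatic group alone means a higher number. No measurement shown gives an explanation for this result.

As far as these compounds go, whether the chlorine, the ring or the loss of the hydrogen-bond donors carries the step remains open. Also open, from the compounds shown here alone, is how a plain phenyl group without chlorine, or a short alkyl chain, would read at this nitrogen in this assay.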